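Removing the Methoxy Group on the Thioether Side Chain

The compounds below may be only part of what the source reports. "The series", "measured", "known", "first", "only" and "open" are said of these compounds alone.

Of the compounds shown here, three have been measured in an assay on isolated protein for inhibition of retinal dehydrogenase 2 (Homo sapiens); on this read-out higher numbers stand for weaker inhibition and lower numbers for stronger inhibition. Compound 1 `CC(Sc1nc2c(cnn2C)c(=O)n1-c1ccc(CO)cc1)c1ccccc1` gives 600 nM, compound 2 `CCC(Sc1nc2c(cnn2C)c(=O)n1-c1ccccc1)c1ccccc1` gives 179 nM, and compound 3 `COc1ccccc1C(C)Sc1nc2c(cnn2C)c(=O)n1-c1ccccc1` gives 136 nM. Compound 3 has the lowest of the three numbers; compound 2 lies within the usual scatter of it, while compound 1 stands beyond it. Compound 4 `CC(Sc1nc2c(cnn2C)c(=O)n1-c1ccccc1)c1ccccc1` has not been measured. It differs from compound 3 by hydrogen in place of methoxy on an aromatic carbon. Within the data shown here, no measured pair shows this change alone, so the expectation rests on the spread seen so far. A modest rise is expected, an estimated step of a 2.2-fold higher number from compound 3 to compound 4 (0.34 log units; beyond the scatter). Compound 4 is expected to give about 300 nM, with a range from 120 nM to 800 nM.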

Compound 4, half-maximal inhibitory concentration: 110 nM
Compound 4: the middle estimate sits 2.7-fold (0.44 log units) above what was measured, outside the stated range (below it).
By their numbers in this assay, from the lowest: compounds 4, 3 and 2 (each within the scatter of the next); then compound 1.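

In this assay the change from 2-methoxyphenyl to phenyl is small (a 1.2-fold lower number from compound 3 to compound 4 (0.09 log units; within the scatter)), so on this aromatic carbon, ortho to a large group, the methoxy group and hydrogen cannot be told apart. Hydrogen in place of methyl on the saturated chain carbon also stays within the scatter (a 1.6-fold lower number from compound 2 to compound 4 (0.21 log units; within the scatter)), whereas hydrogen in place of hydroxymethyl on an aromatic carbon goes beyond it (a 5.5-fold lower number from compound 1 to compound 4 (0.74 log units; beyond the scatter)). No supporting data explain these steps. The compounds shown leave open how an amine or a carboxylic acid would read at the methoxy position.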